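The source may hold more compounds than are shown below. What is called first, only, known or untested is meant among the compounds shown, and "the series" means these compounds.

Working notes on the amide series built on the shared core of compound 1 `O=C(Nc1ccc(Cl)cc1CN1C(=O)c2ccccc2C1=O)C1CCCCC1`. In an assay on CHO cells for positive allosteric modulation of metabotropic glutamate receptor 5 (Homo sapiens), read by FLIPR (on this read-out higher numbers stand for an effect only at larger amounts of compound and lower numbers for an effect already at smaller amounts), compound 1 gives 1500 nM. Compound 2 `COc1ccccc1C(=O)Nc1ccc(Cl)cc1CN1C(=O)c2ccccc2C1=O` carries a 2-methoxyphenyl group on the carbonyl carbon in place of the cyclohexyl. In this assay compound 2 gives > 100000 nM, which is a limit of the assay and not a number. Among the measured compounds shown here, compound 2 therefore stands at the limit, with the limit of > 100000 nM in this assay, at which 1 of the 2 values shown sits, and the step of an at least 66-fold higher number from compound 1 to compound 2 (1.82 log units; beyond the scatter) is the only measured step so far.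

Compound 3 `O=C(Nc1ccc(Cl)cc1CN1C(=O)c2ccccc2C1=O)c1ccccc1` differs from compound 2 by hydrogen in place of methoxy on an aromatic carbon. For the measured compounds named here, the one measured step bears on it only in part: it exchanges cyclohexyl for 2-methoxyphenyl in a single move and does not separate the aromatic ring from the methoxy. Whether the methoxy alone, or the aromatic ring as such, carries the loss seen in compound 2 cannot be read from the two values. The expectation for compound 3 is a lower number than the limit of compound 2, estimated as an at least 5.0-fold lower number from compound 2 to compound 3 (0.69 log units; beyond the scatter), but a number not reaching that of compound 1. Compound 3 is estimated at 20000 nM, with a range of 3000 nM to 100000 nM.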

Compound 3, half-maximal effective concentration: > 100000 nM
Compound 3 was reported as a limit (the forecaster's own chance of this, stated with the estimate: 35%); middle value at least 5.0-fold (0.69 log units) from the limit.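

In this assay compound 3 gives > 100000 nM, which is a limit of the assay and not a number. With phenyl in place of cyclohexyl on the carbonyl carbon and no methoxy present, the change gives an at least 66-fold higher number from compound 1 to compound 3 (1.82 log units; beyond the scatter), so the loss seen in compound 2 does not require the methoxy and already appears with the unsubstituted phenyl. The step between compound 2 and compound 3 cannot be read, and any contribution of the methoxy at this position stays hidden, since both compounds now give the same reading at the ceiling of the assay: the limit of > 100000 nM in this assay, at which 2 of the 3 values shown sit.

Among the groups shown on the carbonyl carbon, only cyclohexyl gives a measurable value, so it remains open whether this reflects a specific need for cyclohexyl or a loss tied to the aromatic ring. A longer alkyl chain on the carbonyl carbon, or an amine or a carboxylic acid on the phenyl ring of compound 3, would show whether a measurable value can be reached outside the cyclohexyl amide.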